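This account rests on a few compounds, and the source may have more. Where it says the series, first, only, none or still open, it means among the compounds named here.

Compound 3, `CC(C(=O)NCc1ccc(C(C)(C)C)nc1SCCCN(C)C)c1ccc(NS(C)(=O)=O)c(F)c1`, carries a (3-(dimethylamino)propyl)sulfanyl group on the shared core. In an assay on cells for antagonist activity at transient receptor potential cation channel subfamily V member 1 (Homo sapiens), read by FLIPR and calcium flux, with a stated time of 6 min (a higher number here means a weaker inhibitor, a lower number a stronger inhibitor), compound 3 gives 51.8 nM, the highest of the three numbers and so the weakest inhibitor measured here. Compound 1, `CC(C)CCOc1nc(C(C)(C)C)ccc1CNC(=O)C(C)c1ccc(NS(C)(=O)=O)c(F)c1`, gives 0.8 nM and compound 2, `CC(C(=O)NCc1ccc(C(C)(C)C)nc1OC1CCCCC1)c1ccc(NS(C)(=O)=O)c(F)c1`, gives 2.5 nM. The steps of a 65-fold higher number from compound 1 to compound 3 (1.81 log units; beyond the scatter) and a 21-fold higher number from compound 2 to compound 3 (1.32 log units; beyond the scatter) show that putting the dimethylamino-bearing chain in place of either plain alkoxy group costs a great deal, while a 3.1-fold higher number from compound 1 to compound 2 (0.49 log units; beyond the scatter) is only modest.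

Compound 4, `CC(C(=O)NCc1ccc(C(C)(C)C)nc1SCc1ccccc1)c1ccc(NS(C)(=O)=O)c(F)c1`, differs from compound 3 in one place: phenyl in place of 2-(dimethylamino)ethyl on a saturated chain carbon bound to a sulfur. This removes the dimethylamino chain that, on the evidence of the two large steps, accounts for most of the weakness of compound 3, and puts in its place a hydrocarbon group comparable in size to those of compounds 1 and 2. For the measured compounds named here, a large step back toward stronger inhibition is therefore expected, though the sulfur link stays, and no measured pair separates that from the rest. The expected step is a 17-fold lower number from compound 3 to compound 4 (1.24 log units; beyond the scatter). Compound 4 is estimated at 3 nM, with a range from 0.8 nM to 12 nM.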

Compound 4, inhibition constant: 4 nM
Compound 4: middle estimate off by 1.3-fold (0.12 log units), on the low side, and the stated range covers the measured number.
By their numbers in this assay, from the lowest: compound 1; then compounds 2 and 4 (each within the scatter of the next); then compound 3.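

In this assay, a sulfur-linked group can do as well as an oxygen-linked one: the step of a 1.6-fold higher number from compound 2 to compound 4 (0.20 log units; within the scatter) leaves benzylsulfanyl level with cyclohexyloxy on this aromatic carbon. Isopentyloxy keeps an edge, with a 5.0-fold higher number from compound 1 to compound 4 (0.70 log units; beyond the scatter), so the choice of group here still matters modestly. With the sulfur kept in both compounds, the change from 2-(dimethylamino)ethyl to phenyl gives a 13-fold lower number from compound 3 to compound 4 (1.11 log units; beyond the scatter), which shows that the large loss in compound 3 does not come from the sulfur link alone.

No measurement here explains these steps. A benzyloxy group on this aromatic carbon would separate the effect of the sulfur link from that of the benzyl group, and a plain pentyl chain on the sulfur would test whether the dimethylamino nitrogen or the chain is what matters.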